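Butylamide replaces methyl ester on the shared core

This account rests on a few compounds, and the source may have more. Where it says the series, first, only, none or still open, it means among the compounds named here.

In a functional assay on PC-3 cells (Homo sapiens) for inhibition, read by sulforhodamine B assay, with a stated time of 72 h (on this read-out higher numbers stand for weaker inhibition and lower numbers for stronger inhibition), compound 3 `COC(=O)c1c(N)sc(-c2ccc(Cl)cc2)c1-c1ccc(Cl)cc1` gives 2780 nM, the lowest of the three numbers shown. Compound 2 `Nc1sc(-c2ccc(Cl)cc2)c(-c2ccc(Cl)cc2)c1C(=O)N1CCCCC1=O` gives 4940 nM, and a 1.8-fold lower number from compound 2 to compound 3 (0.25 log units; within the scatter). Compound 1 `CC(C)(C)NC(=O)c1c(N)sc(-c2ccc(Cl)cc2)c1-c1ccc(Cl)cc1` gives 15100 nM, and a 5.4-fold lower number from compound 1 to compound 3 (0.73 log units; beyond the scatter). Compound 4 `CCCCNC(=O)c1c(N)sc(-c2ccc(Cl)cc2)c1-c1ccc(Cl)cc1` differs from compound 3 by butylamino in place of methoxy on a carbonyl carbon. The step that bears most on this is the one from an amide to the ester, where a 5.4-fold lower number from compound 1 to compound 3 (0.73 log units; beyond the scatter); the step from compound 1 to compound 2 also passed between two carbonyl substituents, where a 3.1-fold lower number from compound 1 to compound 2 (0.49 log units; beyond the scatter). Because compound 1 gives 15100 nM, the butylamino group of compound 4 is expected to land between the amide of compound 1 and the ester of compound 3, so a 2.5-fold higher number from compound 3 to compound 4 (0.40 log units; beyond the scatter) is the estimated step. Compound 4 is therefore expected to give 7000 nM, within 2500 nM to 20000 nM.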

Compound 4, half-maximal inhibitory concentration: 17800 nM
Compound 4: the middle estimate sits 2.5-fold (0.41 log units) below what was measured, and the stated range covers the measured number.
By their numbers in this assay, from the lowest: compounds 3 and 2 (each within the scatter of the next); then compounds 1 and 4 (each within the scatter of the next).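

Butylamino in place of methoxy on a carbonyl carbon brings a 6.4-fold higher number from compound 3 to compound 4 (0.81 log units; beyond the scatter) and butylamino in place of 2-oxopiperidin-1-yl brings a 3.6-fold higher number from compound 2 to compound 4 (0.56 log units; beyond the scatter) so compound 4 stands with compound 1 on the high side of this small set. Butyl in place of tert-butyl on an amide-type nitrogen brings a 1.2-fold higher number from compound 1 to compound 4 (0.07 log units; within the scatter) so these two chains cannot be told apart on this read-out. Nothing shown gives a reason for these steps.

On these data alone, a carboxylic acid or an unsubstituted amide on this carbonyl carbon remains open. So does a shorter chain such as methylamino, which could show whether any amine chain here matches the ester.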